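Benzyl for Methoxyphenyl on the Shared Core

The source may report more compounds than this note shows. Statements on the series, on what has been measured and on what is new or still open speak of the compounds shown alone.

Compound 2 `COc1ccc(-c2nnc(CCC(=O)c3ccc(C)cc3)o2)cc1` stands highest of the two compounds measured in a functional assay on the whole organism (strain Wistar) for inhibition, with Rattus norvegicus as the target, with stated times of 30 min and 3 h, at a dose of 20 mg/kg by the oral route (on this read-out lower numbers stand for less inhibition and higher numbers for more inhibition at the one dose given (going by the name of the read-out)), where compound 2 gives 89.5%. Its nearest neighbour is compound 1 `Cc1ccc(C(=O)CCc2nnc(-c3ccccc3)o2)cc1`, which in this assay gives 49.3%. Among the compounds with values here, the only measured step, a number 40.2 percentage points higher from compound 1 to compound 2 (beyond the scatter), is large and lies well beyond the scatter.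

Compound 3 `Cc1ccc(C(=O)CCc2nnc(Cc3ccccc3)o2)cc1` has not yet been measured. It differs from compound 2 in one place: benzyl in place of 4-methoxyphenyl on an aromatic carbon. Within the data shown here, the measured step of a number 40.2 percentage points higher from compound 1 to compound 2 (beyond the scatter) bears on this change only in part: it concerns the methoxy group that compound 3 also lacks, but compound 3 further exchanges the phenyl for a benzyl, and no measured step speaks to that exchange. With the methoxy gone, the number is expected to fall back toward the level of compound 1, with wide uncertainty because of the unmeasured benzyl exchange.

Compound 3 is therefore expected to give about 45% in this assay, within a range of 20% to 75%. For compound 3 this estimate means an expected step of a number 44.5 percentage points lower from compound 2 to compound 3 (beyond the scatter).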

Compound 3, a percentage reported as inhibition, in the whole organism at one dose (the size of the read-out at that dose, not a potency): 51.9%
Compound 3: middle estimate off by 6.9 percentage points, on the low side; low and high end bracket the measured number.
By their numbers in this assay, from the lowest: compounds 1 and 3 (each within the scatter of the next); then compound 2.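

In this assay, benzyl in place of 4-methoxyphenyl on the aromatic carbon gives a number 37.6 percentage points lower from compound 2 to compound 3 (beyond the scatter) and so shows that the high number of compound 2 is not kept when this group leaves, even though the incoming group also holds a six-membered aromatic ring of carbon only. Benzyl in place of phenyl at the same place gives a number 2.6 percentage points higher from compound 1 to compound 3 (within the scatter) and so adds what the earlier pair could not show: among the compounds without the methoxy group, this exchange leaves no difference that can be told from the scatter, and compound 2 alone stands apart from the other two. Nothing on hand gives a reason for either step.

On these data alone, it remains open whether a methoxy group keeps its link with the high number when it sits on a benzyl group, as in 4-methoxybenzyl, since the methoxy group appears here only on a phenyl ring. As far as these compounds go, it is equally open how an amine or a carboxylic acid on that ring would read, or a longer chain such as phenethyl at this place on the shared core.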